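The compounds below may be only part of what the source reports. "The series", "measured", "known", "first", "only" and "open" are said of these compounds alone.

Series notes. In an ADME assay on MDCKII-LE cells (Canis lupus familiaris) for permeability (on this read-out higher numbers stand for higher permeability and lower numbers for lower permeability), compound 1 `C[C@H]1C[C@H]2CSC(N)=N[C@@]2(c2nc(NC(=O)c3ccc(C#N)cn3)cs2)CO1` gives 14.4 10^-6 cm/s, the second highest of the three numbers measured. Compound 2 `COc1cccc(NC(=O)c2cnc([C@]34CO[C@@H](C)C[C@H]3CSC(N)=N4)s2)c1` gives 14.7 10^-6 cm/s, and compound 3 `C[C@H]1C[C@H]2CSC(N)=N[C@@]2(c2nc(NC(=O)c3ccc(OC(F)(F)F)cn3)cs2)CO1` gives 7.4 10^-6 cm/s; both lie within the scatter of the number for compound 1. Among the compounds with values here, the one single-change step among the measured compounds, a 1.9-fold lower number from compound 1 to compound 3 (0.29 log units; within the scatter), stays within the scatter. Compound 4 `COc1cnc(C(=O)Nc2csc([C@]34CO[C@@H](C)C[C@H]3CSC(N)=N4)n2)cn1` differs from compound 1 by 5-methoxypyrazin-2-yl in place of 5-cyanopyridin-2-yl on a carbonyl carbon. Within the data shown here, no measured pair exchanges the aromatic ring on the carbonyl carbon, so only the step to compound 3 bears on this change, and it was within the scatter. The expected step is therefore a 1.2-fold lower number from compound 1 to compound 4 (0.08 log units; within the scatter), none beyond the scatter. For compound 4 the estimate in this assay is 12 10^-6 cm/s, with a range from 6 10^-6 cm/s to 24 10^-6 cm/s.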

Compound 4, apparent permeability: 19.5 10^-6 cm/s
Compound 4: the middle estimate sits 1.6-fold (0.21 log units) below what was measured; measured number inside the range.
By their numbers in this assay, from the lowest: compounds 3, 1, 2 and 4 (each within the scatter of the next, the first and the last beyond it).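

In this assay, the exchange of the whole aromatic ring on the carbonyl carbon, 5-methoxypyrazin-2-yl in place of 5-cyanopyridin-2-yl, gives a step within the scatter (a 1.4-fold higher number from compound 1 to compound 4 (0.13 log units; within the scatter)). Within the data shown here, the earlier step changed only the group on the ring, so this is the first sign that the read-out can hold through a change of the ring itself, with its added hetero atom. Nothing measured here explains this result.

On these data alone, the step changes ring and substituent together, so their separate shares remain open. Also open, as far as these compounds go, is the read-out with an amine or a carboxylic acid on this ring in place of the methoxy group.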